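The source may hold more compounds than are shown below. What is called first, only, known or untested is meant among the compounds shown, and "the series" means these compounds.

Measured so far in a functional assay on CRL2813 cells (Homo sapiens) for cytotoxicity, read by sulforhodamine B assay, with a stated time of 5 days; on this read-out higher numbers stand for weaker inhibition and lower numbers for stronger inhibition:

Compound 1, `O=C(Nc1cccc(C(=O)O)c1)N[C@H]1CC[C@H](Oc2ccc(F)cc2)CC1`, sits at a limit of the assay rather than a number: > 20000 nM.
Compound 2, `O=C(Nc1cccc(Cl)c1)N[C@H]1CC[C@H](Oc2ccc(F)cc2)CC1`, gives 5900 nM.
Compound 3, `COc1ccccc1NC(=O)N[C@H]1CC[C@H](Oc2ccc(F)cc2)CC1`, also sits at a limit rather than a number: > 20000 nM.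

As far as these compounds go, compound 3 therefore stands at the limit of > 20000 nM in this assay, at which 2 of the 3 values shown sit, so its true position is unknown beyond that limit. Compound 4, `O=C(Nc1ccc(I)cc1)N[C@H]1CC[C@H](Oc2ccc(F)cc2)CC1`, differs from compound 3 in one place: 4-iodophenyl in place of 2-methoxyphenyl on an amide-type nitrogen.

Within the data shown here, two measured steps bear on this change. Going from a 3-chlorophenyl to a 2-methoxyphenyl, the number rose: an at least 3.3-fold higher number from compound 2 to compound 3 (0.53 log units; beyond the scatter). Compound 4 moves back from the 2-methoxyphenyl to a phenyl carrying a halogen, now iodo. Earlier, chloro in place of carboxy also lowered the number: an at least 3.3-fold lower number from compound 1 to compound 2 (0.53 log units; beyond the scatter). Both steps point the same way, so a fall beyond the scatter is expected, though its size from a limit cannot be read exactly; the expected step is an at least 4.0-fold lower number from compound 3 to compound 4 (0.60 log units; beyond the scatter).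

Compound 4 is thus estimated at 5000 nM, with a likely range from 1500 nM to 20000 nM.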

Compound 4, half-maximal inhibitory concentration: 10200 nM
Estimate against measurement, compound 4: 2.0-fold (0.31 log units) below; the range from low to high includes it.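

In this assay, the 4-iodophenyl and 3-chlorophenyl groups on the amide-type nitrogen cannot be told apart, with a 1.7-fold higher number from compound 2 to compound 4 (0.24 log units; within the scatter), so a second halogen-bearing phenyl now gives a readable number in the same range. The steps from the two compounds at the limit are less firm, since the floors of an at least 1.9-fold lower number from compound 3 to compound 4 (0.29 log units; that floor lies within the scatter) and an at least 1.9-fold lower number from compound 1 to compound 4 (0.29 log units; that floor lies within the scatter) do not by themselves clear the scatter. The true size of these two steps stays unknown because both starting compounds sit at a limit: the limit of > 20000 nM in this assay, at which 2 of the 4 values shown sit.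

The 4-iodophenyl and 3-chlorophenyl groups differ in both the halogen and its numbered place, so the role of each remains unseparated. A plain phenyl group or an aminophenyl group on the same nitrogen would test whether a halogen is needed at all.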